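Swapping a hexyl chain for a hydroxycyclohexyl ring

This account rests on a few compounds, and the source may have more. Where it says the series, first, only, none or still open, it means among the compounds named here.

Compound 1 `CCCCCCNc1nc(-c2ccccc2)nc2c1nnn2Cc1ccccc1`: in an assay on isolated protein for binding affinity to adenosine receptor A1 (Bos taurus) (on this read-out higher numbers stand for weaker inhibition and lower numbers for stronger inhibition), compound 1 gives 13200000 nM.
Compound 2 `Clc1ccccc1Cn1nnc2c(NC3CCCCC3)nc(-c3ccccc3)nc21`: in this assay compound 2 gives 34000000 nM.
Compound 3 `CCNc1nc(-c2ccccc2)nc2c1nnn2Cc1ccccc1Cl`: in this assay compound 3 gives 463000000 nM.

Among these three, compound 1 carries the lowest number, so the strongest binding in this assay; compound 2 sits nearest to it, and compound 3 furthest away. Within the data shown here, the one single-point step measured here, a 14-fold higher number from compound 2 to compound 3 (1.13 log units; beyond the scatter), shows that cutting the ring substituent on the amine nitrogen down to a short chain costs a great deal of binding. Compound 1 and compound 2 differ in two places at once, so their values alone cannot say how much the hexyl chain and the cyclohexyl ring differ.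

Compound 4 `O[C@H]1CCCC[C@@H]1Nc1nc(-c2ccccc2)nc2c1nnn2Cc1ccccc1` is built from compound 1 by the change (2-hydroxycyclohexyl in place of hexyl on a nitrogen on an aromatic ring). Among the measured compounds shown here, no measured pair adds a hydroxyl group, so the only guidance is that a six-membered ring on this nitrogen, in compound 2, gave a number in the same broad region as compound 1. Compound 4 is therefore expected to stay close to compound 1, with a step of a 1.5-fold higher number from compound 1 to compound 4 (0.18 log units; within the scatter) that may not pass beyond the scatter. The estimate for compound 4 is 20000000 nM, within a range from 5000000 nM to 100000000 nM.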

Compound 4, inhibition constant: 10300000 nM
The estimate for compound 4 lay 1.9-fold (0.29 log units) above the measured number, within the range that was stated.
By their numbers in this assay, from the lowest: compounds 4 and 1 (each within the scatter of the next); then compound 2; then compound 3.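

In this assay, replacing the hexyl chain with a 2-hydroxycyclohexyl group gives a 1.3-fold lower number from compound 1 to compound 4 (0.11 log units; within the scatter), so the two compounds cannot be told apart. Among these compounds, the earlier compounds showed only that a short ethyl group in place of cyclohexyl on this nitrogen brings a large loss, with a 14-fold higher number from compound 2 to compound 3 (1.13 log units; beyond the scatter), whereas this pair shows that an open chain can give way to a ring carrying a hydroxyl group, with its added hydrogen-bond donor and acceptor and two defined stereocentres, without a change beyond the scatter. Nothing measured here explains why the two groups score alike.

The compounds shown leave open how much of this result belongs to the ring and how much to the hydroxyl group, since compound 2 differs from compound 4 in two places and cannot separate them. Also open, going by these compounds, is whether an amine or a methoxy group in place of the hydroxyl group, or another arrangement of the two stereocentres, would keep the number at this level.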